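5-Substituted Deoxyuridines: From Chloroethenyl to Hydroxy

This account rests on a few compounds, and the source may have more. Where it says the series, first, only, none or still open, it means among the compounds named here.

Measured compounds:
Compound 1 `C=C(Cl)c1cn([C@H]2C[C@H](O)[C@@H](CO)O2)c(=O)[nH]c1=O` — 1660 nM
Compound 2 `O=c1ccn([C@@H]2C[C@H](CO)C[C@@H]2CO)c(=O)[nH]1` — > 200000 nM
Compound 3 `O=c1ccn(COCCO)c(=O)[nH]1` — > 200000 nM

Of the compounds shown here, three have been tested in an ADME assay on L1210/0 cells (Mus musculus) for cytotoxicity, with a stated time of 48 h; on this read-out higher numbers stand for weaker inhibition and lower numbers for stronger inhibition. For the measured compounds named here, compound 1 gives 1660 nM, the only actual number in the set. For compound 2 the result is a limit of the assay, > 200000 nM. For compound 3 the result is likewise a limit, > 200000 nM. Compound 1 therefore stands alone with a measured value, while the other two results stop at the limit of > 200000 nM in this assay, at which 2 of the 3 values shown sit.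

Compound 4 `O=c1[nH]c(=O)n([C@H]2C[C@H](O)[C@@H](CO)O2)cc1O` has not yet been measured. It differs from compound 1 by hydroxy in place of 1-chloroethenyl on an aromatic carbon. Going by the values given here, no pair of measured compounds shares this change, so there is no measured step to lean on; the two limits for compound 2 and compound 3 say only that their cores without a substituent of this kind show no measurable inhibition.

From compound 1 the expectation for compound 4 is a step toward weaker inhibition, of a 72-fold higher number from compound 1 to compound 4 (1.86 log units; beyond the scatter), larger than the usual scatter. The estimate for compound 4 in this assay is 120000 nM, with a range from 20000 nM to 400000 nM, and a real chance that only a limit is reported.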

Compound 4, half-maximal inhibitory concentration: > 200000 nM
Compound 4: a limit, no number (the forecaster's own chance of this, stated with the estimate: 50%); middle value at least 1.6-fold (0.22 log units) away from the limit.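

In this assay compound 4 gives > 200000 nM, which is a limit of the assay and not a number. For the compounds shown here, with the rest of the molecule unchanged, placing hydroxy where 1-chloroethenyl stood gives an at least 120-fold higher number from compound 1 to compound 4 (2.08 log units; beyond the scatter), the first step in this set between compounds that differ in only one place. Compounds 2 and 3 differ from compound 1 in more than one place, so they could not tie its measurable inhibition to this position, whereas this single change shows that hydroxy here does not keep the inhibition within the range the assay can measure, leaving compound 1 as the only compound with a number: the limit of > 200000 nM in this assay, at which 3 of the 4 values shown sit.

Going by these compounds alone, with only two groups compared at this position, it remains open which part of 1-chloroethenyl matters, and an ethenyl group without the chlorine, a single chlorine atom or a longer carbon chain would help to separate those parts. Going by these compounds, the true value of compound 4 also remains unknown, so the full size of the step cannot be stated.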